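Amino for Hydrogen on the Shared Core

The compounds below may be only part of what the source reports. "The series", "measured", "known", "first", "only" and "open" are said of these compounds alone.

Of the compounds shown here, three of a common framework have been measured, and a fourth awaits its number. Compound 1 `CCOC(=O)c1cc(N)c2c(c1)NCC(c1ccccc1)=N2` is the odd one out: in a functional assay on L1210 cells (Mus musculus) (on this read-out higher numbers stand for weaker inhibition and lower numbers for stronger inhibition), compound 1 reaches only the assay limit of > 100000 nM, so no number is known for it. Compound 2 `CCOC(=O)Nc1cc2nc(O)c(-c3ccccc3)nc2c(N)n1` carries a hydroxy on the core and gives 42 nM in this assay. Compound 3 `CCOC(=O)Nc1cc2ncc(-c3ccccc3)nc2c(N)n1` has a hydrogen at that place instead, and in this assay compound 3 gives 300 nM, the higher of the two numbers shown, with compound 2 as its only neighbour. The step of a 7.1-fold higher number from compound 2 to compound 3 (0.85 log units; beyond the scatter) shows that losing the hydroxy weakened inhibition.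

Compound 4 `CCOC(=O)Nc1cc2nc(N)c(-c3ccccc3)nc2c(N)n1` differs from compound 3 by amino in place of hydrogen on an aromatic carbon. Among the measured compounds shown here, the one measured step that bears on this is a 7.1-fold higher number from compound 2 to compound 3 (0.85 log units; beyond the scatter), read in reverse: a hydroxy entering at that place gave a lower number. An amino entering there is expected to act in the same direction, with a step of about a 5.0-fold lower number from compound 3 to compound 4 (0.70 log units; beyond the scatter). Compound 4 is therefore estimated at 60 nM, within a range from 15 nM to 250 nM.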

Compound 4, half-maximal inhibitory concentration: > 30000 nM
Compound 4: only a limit was reported; the forecaster's own chance of this, stated with the estimate: 2%; at least 500-fold (2.69 log units) between middle value and limit.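

Compound 4 gives no number, only a limit of the assay: the limit of > 30000 nM in this assay, at which 1 of the 4 values shown sits.

Even so, the change at this aromatic carbon, next to the ring nitrogen and ortho to a phenyl group, is large: amino in place of hydrogen brings an at least 100-fold higher number from compound 3 to compound 4 (2.00 log units; beyond the scatter), and amino in place of hydroxy brings an at least 710-fold higher number from compound 2 to compound 4 (2.85 log units; beyond the scatter). Among the compounds shown here, compound 2 and compound 3 showed only that hydroxy lowers the number relative to hydrogen, whereas amino raises it, so two small groups entering at the same place push the read-out in opposite directions.

From the compounds shown here alone, the values shown give no reason for this reversal, and how far the true value of compound 4 lies beyond its limit stays unknown. Going by these compounds, whether a methoxy group or a methylamino group at this place would follow hydroxy or amino also remains open.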